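Aryl variation at the saturated ring carbon: cytotoxicity notes

A few compounds are considered here, and "the series" means these few. Any claim that something is new, unique, unknown or untested is made for them only; others in the source may bear on it.

Measured so far:
compound 1 `COc1ccc(C2C(C#N)=C(N)N(c3cc(OC)c(OC)c(OC)c3)C3=C2C(=O)CC(C)(C)C3)cc1` 1%
compound 2 `COc1cc(N2C(N)=C(C#N)C(c3ccccc3O)C3=C2CC(C)(C)CC3=O)cc(OC)c1OC` 0%
compound 3 `COc1cc(N2C(N)=C(C#N)C(c3ccc(OC)c4ccccc34)C3=C2CC(C)(C)CC3=O)cc(OC)c1OC` 30%

In a functional assay on Ehrlich cells (Mus musculus) for cytotoxicity, tested at 25 ug/mL (on this read-out lower numbers stand for a weaker effect and higher numbers for a stronger effect at the one concentration tested), compound 2 stands lowest of the three numbers, with compound 1 within the scatter of it and compound 3 the furthest away. For the measured compounds named here, the only steps beyond the scatter are a number 29 percentage points higher from compound 1 to compound 3 (beyond the scatter) and a number 30 percentage points higher from compound 2 to compound 3 (beyond the scatter), both bringing in the naphthalene; a number 1 percentage points lower from compound 1 to compound 2 (within the scatter) stays within the scatter.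

Compound 4 `COc1cc(N2C(N)=C(C#N)C(c3ccccc3Cl)C3=C2CC(C)(C)CC3=O)cc(OC)c1OC` differs from compound 2 by chloro in place of hydroxy on an aromatic carbon. No measured step exchanges one substituent on the phenyl for another, so nothing shown speaks directly to this change, and the two phenyl compounds sit together near zero. A step of no clear size beyond the scatter is therefore expected, a number 5 percentage points higher from compound 2 to compound 4 (within the scatter). Compound 4 is estimated at 5%, expected to lie between 0% and 25%.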

Compound 4, a percentage reported as activity, at one concentration (the size of the read-out at that concentration, not a potency): 15%
Compound 4: middle estimate off by 10 percentage points, on the low side, within the range that was stated.
By their numbers in this assay, from the lowest: compounds 2 and 1 (each within the scatter of the next); then compound 4; then compound 3.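

In this assay a phenyl compound now rises off the near-zero level: there is a number 15 percentage points higher from compound 2 to compound 4 (beyond the scatter), so at the aromatic carbon ortho to a large group, chloro and hydroxy are not equivalent. The 2-chlorophenyl also separates from the 4-methoxyphenyl, with a number 14 percentage points higher from compound 1 to compound 4 (beyond the scatter), yet it does not reach the naphthalene, with a number 15 percentage points lower from compound 3 to compound 4 (beyond the scatter). Nothing available explains these differences.

Going by these compounds, whether a bromo or an amine in that same place would follow the chloro or the hydroxy remains open.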